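The source may hold more compounds than are shown below. What is called first, only, known or untested is meant among the compounds shown, and "the series" means these compounds.

Compound 1 `CCCCCCCCCCCCCCCCOP(=O)(O)OCCSC(=S)N1CCCCCC1` gives 32100 nM
Compound 2 `CCCCCCCCCCOP(=O)(O)OCCSC(=S)N1CCCC1` gives 56100 nM
Compound 3 `CCCCCCCCCCCCCCCCOP(=O)(O)OCCSC(=S)N1CCN(C)CC1` gives 95200 nM

In a functional assay on PC-3 cells (Homo sapiens) for inhibition, read by MTT assay, with stated times of 18 h and 4 h (a lower number here means a stronger inhibitor, a higher number a weaker inhibitor), compound 1 and compound 2 stand within the scatter of each other, while compound 3 lies beyond the scatter of compound 1. Compound 4 `CCCCCCOP(=O)(O)OCCSC(=S)N1CCCCCC1` keeps the core of compound 1 and differs by hydrogen in place of decyl on a saturated chain carbon, six bonds along the chain from an oxygen on an unsaturated carbon in the chain, with hydrogen in place of decyl. For the measured compounds named here, the single measured step (a 3.0-fold higher number from compound 1 to compound 3 (0.47 log units; beyond the scatter)) leaves the chain unchanged, so it is only a loose guide to size. Compound 2 (56100 nM) differs from compound 1 in more than one place and isolates nothing. A higher number of similar or larger size is expected in this assay with a wide margin. The estimated step is (a 3.4-fold higher number from compound 1 to compound 4 (0.53 log units; beyond the scatter)). Compound 4 is estimated at 110000 nM with an expected range from 45000 nM to 280000 nM in this series.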

Compound 4, half-maximal inhibitory concentration: > 100000 nM
Compound 4 ended at the assay's limit (the forecaster's own chance of this, stated with the estimate: 25%); the middle value lies beyond the limit too.
By their numbers in this assay, from the lowest: compounds 1, 2 and 3 (each within the scatter of the next, the first and the last beyond it). At a limit, above all of these: compound 4.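

In this assay, hydrogen in place of decyl on a saturated chain carbon gives an at least 3.1-fold higher number from compound 1 to compound 4 (0.49 log units; beyond the scatter). For the compounds shown here, this is the first single change in the chain itself: with azepan-1-yl held, the chain moves the number beyond the scatter, whereas the earlier step changed only the group on the thiocarbonyl carbon. Compound 4 reads > 100000 nM, which is a limit and not a number, so the full size of the step stays unknown: the limit of > 100000 nM in this assay, at which 1 of the 4 values shown sits.

On these data alone, with azepan-1-yl held, a chain of intermediate length or a longer chain than in compound 1 remains open. So does an amine or a carboxylic acid on the chain.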